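A few compounds are considered here, and "the series" means these few. Any claim that something is new, unique, unknown or untested is made for them only; others in the source may bear on it.

Measured so far in a functional assay on HeLa cells (Homo sapiens); a lower number here means a stronger inhibitor, a higher number a weaker inhibitor:
Compound 1 `Cc1ccc(C(=O)CC(SCC(=O)O)C(=O)O)cc1`: 17300 nM
Compound 2 `CCc1ccc(C(=O)CC(SCC(=O)O)C(=O)O)cc1`: 4790 nM

Of these two, compound 2 has the lower number, which makes it the stronger inhibitor. The gap is a 3.6-fold lower number from compound 1 to compound 2 (0.56 log units; beyond the scatter), a modest step beyond the scatter. It came from methyl in place of hydrogen on a saturated chain carbon bound to an aromatic carbon.

Compound 3 `CCCCCCCCCCCCc1ccc(C(=O)CC(SCC(=O)O)C(=O)O)cc1` has not yet been measured in this assay. It keeps the shared core and extends the same chain further: decyl in place of hydrogen on a saturated chain carbon, two bonds along the chain from an aromatic carbon. Within the data shown here, only the single measured step bears on this change, and it covers a far smaller extension than a decyl group. The data do not show whether the trend continues to a chain of this length. A step toward a lower number is therefore expected, of about the modest size seen before, though with wide uncertainty that includes no real change. The expected step is a 3.2-fold lower number from compound 2 to compound 3 (0.50 log units; beyond the scatter). Compound 3 is estimated at 1500 nM, with an expected range of 250 nM to 9000 nM.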

Compound 3, half-maximal inhibitory concentration: 1710 nM
The estimate for compound 3 lay 1.1-fold (0.06 log units) below the measured number; measured number inside the range.
By their numbers in this assay, from the lowest: compound 3; then compound 2; then compound 1.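

In this assay, the chain on the shared core can grow well beyond the ethyl of compound 2 and the number still falls: decyl in place of hydrogen on a saturated chain carbon, two bonds along the chain from an aromatic carbon, gives a 2.8-fold lower number from compound 2 to compound 3 (0.45 log units; beyond the scatter). The earlier step, a 3.6-fold lower number from compound 1 to compound 2 (0.56 log units; beyond the scatter), showed only the effect of adding methyl, whereas this one shows that the chain can take on 10 heavy atoms, all carbon, without losing strength, and that the direction of change holds across all three compounds. The step is again modest, however, so this much larger addition does not bring a correspondingly large drop in the number, and nothing available explains the effect of the longer chain.

On these data alone, with only these three compounds, it remains open how the number changes at intermediate lengths, such as a butyl or hexyl chain, and whether a still longer chain would lower it further or reverse the trend. As far as these compounds go, it is also open whether the chain itself matters, or whether a phenyl ring, an amine or a carboxylic acid at its end would serve as well.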